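The source may hold more compounds than are shown below. What is called first, only, known or untested is meant among the compounds shown, and "the series" means these compounds.

The three compounds measured so far:

Compound 1, `O=C(CCCCC1CCSS1)NCc1cn(CCCOc2ccc3ccc(=O)oc3c2)nn1`: 43.5%
Compound 2, `COc1ccc(-c2cc3ccc(OCCCCn4cc(CNC(=O)CCCCC5CCSS5)nn4)cc3oc2=O)cc1`: 55.3%
Compound 3, `CCOC(=O)c1cc2ccc(OCCCCCn3cc(CNC(=O)CCCCC4CCSS4)nn3)cc2oc1=O`: 40.7%

In a functional assay on PC-12 cells (Rattus norvegicus) for cytotoxicity, read by MTT assay, with stated times of 3 h and 2 h, tested at 50 uM (a higher number here means a stronger effect of the compound at the concentration tested, a lower number a weaker effect), compound 3 gives 40.7%, the lowest of the three numbers. Compound 1 comes nearest to it, and the two lie within the scatter of each other, so no order between them can be claimed. Compound 2 stands furthest away, its number being higher by an amount beyond the scatter.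

Compound 4, `O=C(CCCCC1CCSS1)NCc1cn(CCCCCOc2ccc3cc(-c4ccc(Br)cc4)c(=O)oc3c2)nn1`, has not yet been measured in this assay. It differs from compound 3 in one place: 4-bromophenyl in place of ethoxycarbonyl on an aromatic carbon. Going by the values given here, no pair of measured compounds differs in only one place, so no measured step can guide the expectation directly. Among the compounds with values here, what the numbers show is that the one compound carrying a further aromatic ring on the shared core, compound 2, gives the highest value. On that basis the step from compound 3 to compound 4 is expected to be a modest rise, a number 9.3 percentage points higher from compound 3 to compound 4 (within the scatter), though it may well stay within the scatter. Compound 4 is therefore estimated at 50%, with a range from 38% to 62%.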

Compound 4, a percentage reported as activity, at one concentration (the size of the read-out at that concentration, not a potency): 53.6%
Beside the measured number, compound 4's estimate is 3.6 percentage points below it; the range from low to high includes it.
By their numbers in this assay, from the lowest: compounds 3 and 1 (each within the scatter of the next); then compounds 4 and 2 (each within the scatter of the next).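

In this assay, going by these compounds alone, the exchange of ethoxycarbonyl for 4-bromophenyl gives a number 12.9 percentage points higher from compound 3 to compound 4 (beyond the scatter), the first step in this set that can be read between compounds differing in one place. It shows that the read-out responds to what sits on this aromatic carbon, two atoms from the ring oxygen, when a group with no ring and two hydrogen-bond acceptors gives way to a six-membered aromatic ring of carbon only, with bromine on it. Nothing measured here accounts for the step, and the part of the exchange that carries it remains unassigned.

On these data alone, it remains open whether an unsubstituted phenyl on this carbon would read like 4-bromophenyl, which would separate the ring from the bromine. Also open, as far as these compounds go, are how a carboxylic acid in place of the ethoxycarbonyl would read and whether the step would hold with a shorter chain.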